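The compounds below may be only part of what the source reports. "The series", "measured", "known", "first", "only" and "open" are said of these compounds alone.

Among the compounds with values here, in a functional assay on the whole organism for inhibition, with Rattus norvegicus as the target, read by paw edema, with stated times of 30 min and 2 h, at a dose of 0.28 mmol/kg by the oral route (on this read-out lower numbers stand for less inhibition and higher numbers for more inhibition at the one dose given (going by the name of the read-out)), compound 1 `COc1ccc(NC(=O)c2nc(-c3cc(OC)c(OC)c(OC)c3)n(-c3ccc(OC)cc3)n2)cc1` gives 45%, while compound 2 `COc1ccc(-n2nc(C(=O)Nc3ccc(C(=O)O)cc3)nc2-c2cc(OC)c(OC)c(OC)c2)cc1` gives 57%, the higher of the two numbers; the single measured step, a number 12 percentage points higher from compound 1 to compound 2 (beyond the scatter), lies beyond the scatter. Compound 3 `COc1ccc(-n2nc(C(=O)Nc3ccccc3)nc2-c2cc(OC)c(OC)c(OC)c2)cc1` differs from compound 2 by hydrogen in place of carboxy on an aromatic carbon. Within the data shown here, only that one step bears on the change, and it concerned a carboxy entering rather than leaving, so its removal is expected to give back part of that gain. The step to compound 3 is therefore expected to be a number 9 percentage points lower from compound 2 to compound 3 (within the scatter). Compound 3 is estimated at 48%, within 35% to 62%.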

Compound 3, a percentage reported as inhibition, in the whole organism at one dose (the size of the read-out at that dose, not a potency): 51%
Compound 3: middle estimate off by 3 percentage points, on the low side; the range from low to high includes it.
By their numbers in this assay, from the lowest: compounds 1, 3 and 2 (each within the scatter of the next, the first and the last beyond it).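

In this assay, hydrogen in place of carboxy at this place on the ring gives a number 6 percentage points lower from compound 2 to compound 3 (within the scatter), and hydrogen in place of methoxy gives a number 6 percentage points higher from compound 1 to compound 3 (within the scatter). The phenyl of compound 3 therefore cannot be told apart from either substituted ring, and at this position only carboxy against methoxy separates beyond the scatter. No available evidence explains this result.

Going by these compounds, how an amine, a fluorine atom or a longer chain ending in a carboxylic acid would read at this position stays open. So does whether carboxy would read the same elsewhere on this ring.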